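Hydrogen for benzyloxy on compound 2

The source may report more compounds than this note shows. Statements on the series, on what has been measured and on what is new or still open speak of the compounds shown alone.

For the measured compounds named here, in a functional assay on PC-3 cells (Homo sapiens) for cytotoxicity, read by sulforhodamine B assay, with a stated time of 48 h (a lower number here means a stronger inhibitor, a higher number a weaker inhibitor), the series so far returns only limits. Compound 1 (`O=[N+]([O-])c1ccc(-c2nccn2S(=O)(=O)c2ccccc2)cc1`) gives > 10000 nM as a limit of the assay. Compound 2 (`O=S(=O)(c1ccccc1)n1ccnc1-c1ccc(OCc2ccccc2)cc1`) gives > 10000 nM as a limit too. Compound 3 (`COc1ccc(C(=O)n2ccnc2-c2ccccc2)cc1`) also gives > 10000 nM as a limit. Compound 2 therefore has no number to stand on, only its place among the compounds at that limit (the limit of > 10000 nM in this assay, at which 3 of the 3 values shown sit).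

Compound 4 (`O=S(=O)(c1ccccc1)n1ccnc1-c1ccccc1`) carries hydrogen in place of benzyloxy on an aromatic carbon, para to a large group (hydrogen in place of benzyloxy on an aromatic carbon). Going by the values given here, the one measured step at this place (a step that the two limits leave unreadable from compound 1 to compound 2) has no readable size, so it gives neither a size nor a direction to carry over. No step beyond the scatter is expected, and the estimated step (a step that the limit leaves unreadable from compound 2 to compound 4) is correspondingly small and uncertain. In this assay the estimate for compound 4 is 12000 nM with an expected range of 4000 nM to 40000 nM and a limit of the assay as the likeliest expected outcome.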

Compound 4, half-maximal inhibitory concentration: > 10000 nM
Compound 4: only a limit was reported (the forecaster's own chance of this, stated with the estimate: 85%); the middle value lies beyond the limit too.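

No step can be read from compound 2 to compound 4 or from compound 1 to compound 4, since both sides of each pair are limits only: the limit of > 10000 nM in this assay, at which 4 of the 4 values shown sit. The compounds shown leave open whether any change on the shared core separates them in this assay.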